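The compounds below may be only part of what the source reports. "The series", "measured", "known", "first", "only" and "open" are said of these compounds alone.

Three compounds share one core and differ only in the aryl group carried on the amide nitrogen. Compound 1 `O=C(CSc1nc(Nc2ccccc2)c2ccccc2n1)Nc1ccccc1Br` bears a 2-bromophenyl there, compound 2 `O=C(CSc1nc(Nc2ccccc2)c2ccccc2n1)Nc1cccc(F)c1` a 3-fluorophenyl, and compound 3 `O=C(CSc1nc(Nc2ccccc2)c2ccccc2n1)Nc1cccc([N+](=O)[O-])c1` a 3-nitrophenyl. In a functional assay on NCI-H1975 cells (Homo sapiens) for inhibition, read by MTT assay, with a stated time of 72 h (a higher number here means a weaker inhibitor, a lower number a stronger inhibitor), compound 1 gives 10300 nM; compound 2 gives 6790 nM; compound 3 gives 17900 nM. Compound 3 thus has the highest of the three numbers, but against compound 1 the gap is a 1.7-fold higher number from compound 1 to compound 3 (0.24 log units; within the scatter), while against compound 2 it is a 2.6-fold higher number from compound 2 to compound 3 (0.42 log units; beyond the scatter). The remaining step is a 1.5-fold lower number from compound 1 to compound 2 (0.18 log units; within the scatter).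

Compound 4 `O=C(CSc1nc(Nc2ccccc2)c2ccccc2n1)Nc1ccc(F)c(Cl)c1` is obtained from compound 3 by the change (3-chloro-4-fluorophenyl in place of 3-nitrophenyl on an amide-type nitrogen). Going by the values given here, the one step that bears directly on this is the fluoro-to-nitro swap, since the reverse direction, a halogen in place of the nitro group, is what compound 4 brings; that step was a 2.6-fold higher number from compound 2 to compound 3 (0.42 log units; beyond the scatter). Among the compounds with values here, compound 4 also carries a second halogen, for which no measured step exists, so its effect is unknown. Compound 4 is therefore expected to sit near compound 2 rather than compound 3. The step from compound 3 to compound 4 is estimated as a 2.4-fold lower number from compound 3 to compound 4 (0.38 log units; beyond the scatter). For compound 4 the estimate in this assay is 7500 nM, with a range from 3500 nM to 16000 nM.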

Compound 4, half-maximal inhibitory concentration: 9390 nM
The estimate for compound 4 lay 1.3-fold (0.10 log units) below the measured number; measured number inside the range.
By their numbers in this assay, from the lowest: compounds 2, 4, 1 and 3 (each within the scatter of the next, the first and the last beyond it).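

In this assay the change from 3-nitrophenyl to 3-chloro-4-fluorophenyl on the amide-type nitrogen gives a 1.9-fold lower number from compound 3 to compound 4 (0.28 log units; within the scatter), so this swap cannot be told apart from the ordinary spread of repeat measurements, even though the earlier swap of fluoro for nitro gave a 2.6-fold higher number from compound 2 to compound 3 (0.42 log units; beyond the scatter). Adding the second halogen, whose effect could not be judged before, leaves no readable mark, with a 1.4-fold higher number from compound 2 to compound 4 (0.14 log units; within the scatter), and the 2-bromophenyl group gives an equally unresolved comparison, with a 1.1-fold lower number from compound 1 to compound 4 (0.04 log units; within the scatter); the three halogen-bearing aryl groups therefore cannot be separated at this position, while the 3-nitrophenyl group can be separated only from the 3-fluorophenyl group. No measurement is available that explains these results.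

As far as these compounds go, every group at this position is a substituted phenyl ring, so it remains open whether a cyclohexyl ring or a chain ending in an amine would shift the number more clearly. The rest of the shared core stays the same throughout, which leaves open what a carboxylic acid or a methoxy group placed elsewhere on it would do.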